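Chloro in place of methyl at the aryl amide of compound 1

This account rests on a few compounds, and the source may have more. Where it says the series, first, only, none or still open, it means among the compounds named here.

Compound 1 `COc1ncc(-c2ccc3c(c2)N(c2ccc(C)cc2)C(=O)CO3)cc1NS(=O)(=O)c1ccc(F)cc1` was tested in a functional assay on HCT-116 cells (Homo sapiens) for antiproliferative activity, read by MTT assay, with a stated time of 72 h (on this read-out higher numbers stand for weaker inhibition and lower numbers for stronger inhibition), and gives 22700 nM. Compound 3 `COc1cccc(N2C(=O)COc3ccc(-c4ccc(O)cc4)cc32)c1` gives 15300 nM, and the gap between compound 3 and compound 1 lies within the scatter of repeated measurements. Compound 2 `COc1ccc(N2C(=O)COc3ccc(-c4cnc5ccccc5c4)cc32)cc1` reaches only the limit of the assay, > 40000 nM; (the limit of > 40000 nM in this assay, at which 1 of the 3 values shown sits). Compound 4 `COc1ncc(-c2ccc3c(c2)N(c2ccc(Cl)cc2)C(=O)CO3)cc1NS(=O)(=O)c1ccc(F)cc1` has not yet been measured. It differs from compound 1 by chloro in place of methyl on an aromatic carbon. Within the data shown here, no measured pair shows this kind of change, so the step of a 1.1-fold lower number from compound 1 to compound 4 (0.05 log units; within the scatter) is expected to stay within the scatter, in neither direction beyond it. Compound 4 is therefore estimated to give about 20000 nM, with a range from 8000 nM to 45000 nM.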

Compound 4, half-maximal inhibitory concentration: 19200 nM
Compound 4: middle estimate off by 1.0-fold (0.02 log units), on the high side; low and high end bracket the measured number.
By their numbers in this assay, from the lowest: compounds 3, 4 and 1 (each within the scatter of the next). At a limit, above all of these: compound 2.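

In this assay, the exchange of methyl for chloro gives the first step read at this position, on an aromatic carbon para to a large group: a 1.2-fold lower number from compound 1 to compound 4 (0.07 log units; within the scatter) and so methyl and chloro cannot be told apart here. The compounds shown offer no cause for this result.

As far as these compounds go, whether an amine or a carboxylic acid in the same place would give a step beyond the scatter remains open. So does whether a single change elsewhere on the core of compound 1 would do so.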